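Dropping the pyrazole methyl in an EZH2 Y641N series

This account rests on a few compounds, and the source may have more. Where it says the series, first, only, none or still open, it means among the compounds named here.

Measured compounds:
compound 1, `Cc1cc(C)c(CN2CCc3c(F)cc(O[C@@H]4CCOC4)c(Cl)c3C2=O)c(=O)[nH]1`, 260 nM
compound 2, `Cc1cc(C)c(CN2CCc3c(C)cc(O[C@@H]4CCOC4)c(Cl)c3C2=O)c(=O)[nH]1`, 61 nM
compound 3, `Cc1cc(C)c(CN2CCc3c(Cl)cc(-c4cn[nH]c4C)c(Cl)c3C2=O)c(=O)[nH]1`, 110 nM

In an assay on Sf9 cells for inhibition of histone-lysine N-methyltransferase EZH2 variant Y641N (Homo sapiens), read by scintillation counting, with a stated time of 60 min, in the presence of a further agent that is not named here (a higher number here means a weaker inhibitor, a lower number a stronger inhibitor), compound 1 gives 260 nM. Among the measured compounds shown here, compound 2 gives 61 nM, and the step of a 4.3-fold lower number from compound 1 to compound 2 (0.63 log units; beyond the scatter) is the only single-point change measured so far. Compound 3 gives 110 nM; this number is close to that of compound 2, within the scatter, while its gap to compound 1 is beyond the scatter, so compound 3 is a stronger inhibitor than compound 1.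

Compound 4, `Cc1cc(C)c(CN2CCc3c(Cl)cc(-c4cn[nH]c4)c(Cl)c3C2=O)c(=O)[nH]1`, differs from compound 3 by hydrogen in place of methyl on an aromatic carbon, that is, 5-methyl-1H-pyrazol-4-yl becomes 1H-pyrazol-4-yl. For the measured compounds named here, no measured step touches this five-membered aromatic ring with 2 nitrogen; the one measured step concerns the shared core, not the pyrazole, so it does not bear on the change directly. Without a relevant precedent, the expected step of a 1.4-fold higher number from compound 3 to compound 4 (0.13 log units; within the scatter) is small, leaning to a slightly weaker inhibitor but within the scatter. Compound 4 is therefore estimated at 150 nM, with a range from 55 nM to 400 nM.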

Compound 4, half-maximal inhibitory concentration: 270 nM
Estimate against measurement, compound 4: 1.8-fold (0.26 log units) below; the range from low to high includes it.
By their numbers in this assay, from the lowest: compounds 2 and 3 (each within the scatter of the next); then compounds 1 and 4 (each within the scatter of the next).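

In this assay, among the compounds shown here, taking the methyl off the pyrazole, so that 5-methyl-1H-pyrazol-4-yl becomes 1H-pyrazol-4-yl, gives a 2.5-fold higher number from compound 3 to compound 4 (0.39 log units; beyond the scatter), the first measured step at this ring, modest but beyond the scatter. The methyl on this aromatic carbon, next to the ring nitrogen, therefore goes with the stronger inhibitor in this pair, although the reading rests on this single pair on the core of compound 3. Nothing available here accounts for the size of this step.

As far as these compounds go, whether an ethyl or a cyclopropyl group on this same carbon would push the number lower than methyl does remains open. Also open, from the compounds shown here alone, is whether the methyl would have a step of similar size on a core carrying a different group from the chloro of compound 3.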